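The source may report more compounds than this note shows. Statements on the series, on what has been measured and on what is new or still open speak of the compounds shown alone.

Measured compounds:
compound 1, `Cc1cc(C)c(Oc2cc(Nc3ccc(C#N)cc3)ncc2C(=O)NCc2cn(Cc3cccc(C#N)c3)nn2)c(C)c1`: >= 129000 nM
compound 2, `Cc1cc(C)c(Oc2cc(Nc3ccc(C#N)cc3)ncc2C(=O)NCc2cn(CC(=O)N3CCCC3)nn2)c(C)c1`: 58100 nM

Within the data shown here, in an ADME assay on MT4 cells (Homo sapiens) for cytotoxicity, read by MTT assay, with a stated time of 5 days (a higher number here means that more compound is tolerated, a lower number that less compound is tolerated), compound 2 gives 58100 nM, the only plain number among the two values shown. Compound 1 reaches only a limit of the assay, (the limit of >= 129000 nM in this assay, at which 1 of the 2 values shown sits). Among the measured compounds shown here, the single measured step, an at least 2.2-fold lower number from compound 1 to compound 2 (0.34 log units; beyond the scatter), moves from an aromatic ring to an amide on that chain carbon and lowers the number. Compound 3, `Cc1cc(C)c(Oc2cc(Nc3ccc(C#N)cc3)ncc2C(=O)NCc2cn(Cc3cccc([N+](=O)[O-])c3)nn2)c(C)c1`, reverses that kind of change: 3-nitrophenyl in place of (pyrrolidin-1-yl)carbonyl on a saturated chain carbon bound to an aromatic nitrogen. For the measured compounds named here, the step from compound 1 to compound 2 is the only evidence that bears on it, and read backwards it points to a higher number in this assay when an aryl ring returns; 3-nitrophenyl is a close kin of the 3-cyanophenyl of compound 1, so a rise of about that size is expected, a 2.0-fold higher number from compound 2 to compound 3 (0.30 log units; within the scatter), with a fair chance that only a limit is recorded again. Compound 3 is therefore expected to give 115000 nM, between 50000 nM and 200000 nM.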

Compound 3, half-maximal cytotoxic concentration: >= 156000 nM
Compound 3: only a limit was reported; the forecaster's own chance of this, stated with the estimate: 50%; middle value at least 1.3-fold (0.13 log units) away from the limit.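

In this assay, the change from an amide back to an aryl ring on a saturated chain carbon bound to an aromatic nitrogen now has a second pair behind it: an at least 2.6-fold higher number from compound 2 to compound 3 (0.42 log units; beyond the scatter). Compound 3 is recorded only as a limit of the assay: the limit of >= 156000 nM in this assay, at which 1 of the 3 values shown sits. Thus 3-nitrophenyl, like 3-cyanophenyl in compound 1, leaves a limit where (pyrrolidin-1-yl)carbonyl in compound 2 gives a plain number, while the step from nitrile to nitro on the aromatic carbon cannot be read from two limits.

From the compounds shown here alone, how far compound 1 and compound 3 lie beyond their limits stays open. Also open, going by these compounds, is whether a benzyl ring carrying an amine or a carboxylic acid, or an open-chain dimethylamide in place of the pyrrolidine amide, would follow either pattern.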